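A few compounds are considered here, and "the series" means these few. Any claim that something is new, unique, unknown or untested is made for them only; others in the source may bear on it.

Notes on the shared core, read in a functional assay on MCF7 cells (Homo sapiens) for inhibition, read by sulforhodamine B assay; a lower number here means a stronger inhibitor, a higher number a weaker inhibitor. Compound 1 `CCCc1ccc(NC2=CC(=O)c3c(nc4n3[C@H]3OC[C@@H](O)[C@H]3OC4)C2=O)cc1` carries 4-propylphenyl on the amine nitrogen. In this assay compound 1 reaches only a limit, > 4000 nM. Compound 2 `O=C1C(NC2CC2)=CC(=O)c2c1nc1n2[C@H]2OC[C@@H](O)[C@H]2OC1` carries cyclopropyl in that place. In this assay compound 2 also returns only a limit, > 16000 nM. Compound 3 `CCCN(CCC)C1=CC(=O)c2c(nc3n2[C@H]2OC[C@@H](O)[C@H]2OC3)C1=O` carries dipropylamino on the double-bonded ring carbon. In this assay compound 3 likewise stops at a limit, > 16000 nM. The steps a step that the two limits leave unreadable from compound 1 to compound 2 and a step that the two limits leave unreadable from compound 2 to compound 3 therefore cannot be sized, since two values sit at the limit of > 16000 nM in this assay, at which 2 of the 3 values shown sit, and one at the limit of > 4000 nM in this assay, at which 1 of the 3 values shown sits. Compound 3 thus stands at the higher of the two limits, with no number beneath it.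

Compound 4 `O=C1C(Nc2ccc(I)cc2)=CC(=O)c2c1nc1n2[C@H]2OC[C@@H](O)[C@H]2OC1` arises from compound 3 by (4-iodophenyl)amino in place of dipropylamino on a double-bonded ring carbon. Among the measured compounds shown here, no measured step reads on an aryl amine in this position; the nearest measured group is that of compound 1, which also ended at a limit, > 4000 nM. The step of an at least 1.3-fold lower number from compound 3 to compound 4 (0.12 log units; that floor lies within the scatter) is expected to stay within the scatter, with no direction readable. For compound 4 the expected value in this assay is 12000 nM, within 2500 nM to 60000 nM, and most likely once more a limit.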

Compound 4, half-maximal inhibitory concentration: 3890 nM
Compound 4: middle estimate off by 3.1-fold (0.49 log units), on the high side; measured number inside the range.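

In this assay, compound 4 is the first compound shown to give a number rather than a limit on this double-bonded ring carbon, with (4-iodophenyl)amino in that place. The change from dipropylamino reads as an at least 4.1-fold lower number from compound 3 to compound 4 (0.61 log units; beyond the scatter), and the change from cyclopropyl on the amine nitrogen reads as an at least 4.1-fold lower number from compound 2 to compound 4 (0.61 log units; beyond the scatter), so both true sizes may be larger. Iodo in place of propyl on an aromatic carbon reads only as an at least 1.0-fold lower number from compound 1 to compound 4 (0.01 log units; that floor lies within the scatter), so the two aryl amines cannot be ordered, and compound 1 rests on a limit: the limit of > 4000 nM in this assay, at which 1 of the 4 values shown sits.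

The steps from compound 1 to compound 2 and from compound 2 to compound 3 cannot be read. Open too, on these data alone, is whether methoxy or a carboxylic acid in place of iodo on the aromatic ring would move the number.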